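From 1H-pyrrol-2-yl to thiophen-2-yl on a carbonyl carbon

The source may hold more compounds than are shown below. What is called first, only, known or untested is meant among the compounds shown, and "the series" means these compounds.

Going by the values given here, in a functional assay on NCI-H1650 cells (Homo sapiens) for inhibition, read by sulforhodamine B assay, with a stated time of 3 days (a lower number here means a stronger inhibitor, a higher number a weaker inhibitor), compound 1 `O=C1Nc2ccc(F)cc2/C1=C\C(=O)c1ccc(O)cc1F` gives 3460 nM and compound 2 `O=C1Nc2ccc(F)cc2/C1=C\C(=O)c1ccc[nH]1` gives 2840 nM, so compound 2 stands within the scatter of the only other measured value. Compound 3 `O=C1Nc2ccc(F)cc2/C1=C\C(=O)c1cccs1` carries thiophen-2-yl in place of 1H-pyrrol-2-yl on a carbonyl carbon. Among the compounds with values here, no measured pair differing in one place shows what such a change does, so no step beyond the scatter is expected in this assay, in either direction. The expected step of a 1.1-fold lower number from compound 2 to compound 3 (0.06 log units; within the scatter) is small. The estimated value for compound 3 is 2500 nM, with an expected range of 900 nM to 7000 nM.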

Compound 3, half-maximal inhibitory concentration: 3220 nM
Beside the measured number, compound 3's estimate is 1.3-fold (0.11 log units) below it, and the stated range covers the measured number.
By their numbers in this assay, from the lowest: compounds 2, 3 and 1 (each within the scatter of the next).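

In this assay, going by these compounds alone, the step of a 1.1-fold higher number from compound 2 to compound 3 (0.05 log units; within the scatter) gives the first reading at this position on a carbonyl carbon: thiophen-2-yl in place of 1H-pyrrol-2-yl leaves the two values within the scatter. The hydrogen-bond donor counted on 1H-pyrrol-2-yl is therefore not needed here to hold the number in this range. No measured evidence bears on the reason for this result. Going by these compounds, whether a carboxylic acid or an aminomethyl group on the thiophen-2-yl ring would move the number beyond the scatter remains open.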